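The Same Side-Chain Swap Tried on a Weaker Core

The source may hold more compounds than are shown below. What is called first, only, known or untested is meant among the compounds shown, and "the series" means these compounds.

Three compounds have been measured in a functional assay on SNU-638 cells (Homo sapiens) for antiproliferative activity, read by sulforhodamine B assay, with a stated time of 72 h; a lower number here means a stronger inhibitor, a higher number a weaker inhibitor:

compound 1, `COc1ncc(-c2ccc3c(c2)N(CCC(=O)N2CCOCC2)C(=O)CO3)cc1NS(=O)(=O)c1ccc(F)cc1F`, gives 5770 nM
compound 2, `COc1ncc(-c2ccc3c(c2)N(CCCn2ccccc2=O)C(=O)CO3)cc1NS(=O)(=O)c1ccc(F)cc1F`, gives 6760 nM
compound 3, `CCCCS(=O)(=O)Nc1cc(-c2ccc3c(c2)N(CCC(=O)N2CCOCC2)C(=O)CO3)cnc1OC`, gives 41900 nM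

Compounds 1 and 2 share one core and differ only in the side chain: a group of 8 heavy atoms (6 carbon, 1 nitrogen, 1 oxygen; one six-membered aromatic ring with 1 hetero atom) in place of a group of 8 heavy atoms (5 carbon, 1 nitrogen, 2 oxygen; one six-membered non-aromatic ring with 2 hetero atoms), on a saturated chain carbon, two bonds along the chain from an amide-type nitrogen in a ring. This change made a 1.2-fold higher number from compound 1 to compound 2 (0.07 log units; within the scatter). Compound 3 carries a different core; its difference from compound 1 is butyl in place of 2,4-difluorophenyl on a sulfonyl sulfur, and that change made a 7.3-fold higher number from compound 1 to compound 3 (0.86 log units; beyond the scatter). Compound 3 is thus the weakest of the three measured compounds, its steps to both others lying beyond the scatter.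

Compound 4, `CCCCS(=O)(=O)Nc1cc(-c2ccc3c(c2)N(CCCn2ccccc2=O)C(=O)CO3)cnc1OC`, has not yet been measured in this assay. It stands to compound 3 as compound 2 stands to compound 1: a group of 8 heavy atoms (6 carbon, 1 nitrogen, 1 oxygen; one six-membered aromatic ring with 1 hetero atom) in place of a group of 8 heavy atoms (5 carbon, 1 nitrogen, 2 oxygen; one six-membered non-aromatic ring with 2 hetero atoms), on a saturated chain carbon, two bonds along the chain from an amide-type nitrogen in a ring. The place of the change reads the same in both pairs, so this is the same change, now made on the core of compound 3. Among the compounds with values here, the only guide to its effect is the single earlier instance, which made a 1.2-fold higher number from compound 1 to compound 2 (0.07 log units; within the scatter). Whether the swap behaves alike on the core of compound 3 cannot be known from three compounds. Compound 4 is expected to sit close to compound 3, with an estimated step of a 1.2-fold higher number from compound 3 to compound 4 (0.08 log units; within the scatter), because compound 3 gives 41900 nM and the earlier swap stayed within the scatter. Compound 4 is therefore estimated at 50000 nM, expected to fall between 22000 nM and 115000 nM.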

Compound 4, half-maximal inhibitory concentration: 44300 nM
Estimate against measurement, compound 4: 1.1-fold (0.05 log units) above, and the stated range covers the measured number.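

In this assay, within the data shown here, the group entering in place of (morpholin-4-yl)carbonyl gave a 1.1-fold higher number from compound 3 to compound 4 (0.02 log units; within the scatter), so on the core of compound 3, as on the core of compound 1, this change produced no step beyond the scatter: the same change on two cores in this assay, a 1.2-fold higher number (0.07 log units; within the scatter) from compound 1 to compound 2 and a 1.1-fold higher number (0.02 log units; within the scatter) from compound 3 to compound 4, 1.1-fold (0.04 log units) apart, within the scatter of two such steps The other change, butyl in place of 2,4-difluorophenyl on a sulfonyl sulfur, was also carried across, now with the new side chain in place, and gave a 6.6-fold higher number from compound 2 to compound 4 (0.82 log units; beyond the scatter), a step that matches the earlier one: the same change on two cores in this assay, a 7.3-fold higher number (0.86 log units; beyond the scatter) from compound 1 to compound 3 and a 6.6-fold higher number (0.82 log units; beyond the scatter) from compound 2 to compound 4, 1.1-fold (0.04 log units) apart, within the scatter of two such steps Within these four compounds the two changes therefore read as independent of each other, but this rests on only two pairs for each change, and it does not show why the side-chain swap makes no visible difference or whether the same would hold on a core giving much lower numbers.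

The compounds shown leave open whether a side chain ending in an open-chain amine or a carboxylic acid, or a longer chain carrying either of the same two end groups, would also leave the number within the scatter. They also leave open how a methyl or an unsubstituted phenyl on the sulfonyl sulfur would compare with butyl and 2,4-difluorophenyl.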